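A few compounds are considered here, and "the series" means these few. Any claim that something is new, unique, unknown or untested is made for them only; others in the source may bear on it.

Working notes on the series.

Compounds 1 and 2 share one core; compound 1 is `Cc1ccc(-c2nn(-c3ccc(Cl)cc3)cc2/C=C\C(=O)c2ccc(Cl)cc2)cc1` and compound 2 is `COc1ccc(-c2nn(-c3ccc(Cl)cc3)cc2/C=C\C(=O)c2ccc(Cl)cc2)cc1`. In a functional assay on the whole organism (strain Wistar albino) for inhibition, with Rattus norvegicus as the target, read by paw edema, with stated times of 1 h and 3 h, at a dose of 0.32 mmol/kg by the intraperitoneal route (a higher number here means more inhibition at the dose given (going by the name of the read-out), a lower number less inhibition), compound 1 gives 61.4%, and compound 2 gives 66.4%. Within the data shown here, the only change between them is methoxy in place of methyl on an aromatic carbon; the step it made is a number 5 percentage points higher from compound 1 to compound 2 (within the scatter).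

Compound 3, `Cc1ccc(-c2nn(-c3ccc(S(N)(=O)=O)cc3)cc2C(CC(=O)c2ccc(Cl)cc2)C(=O)c2ccc(F)cc2)cc1`, belongs to a second core; how this core differs from that of compound 1 is not broken down here, as the two differ in more than one place. In this assay compound 3 gives 56.2%. Against compound 1 this lies within the scatter; against compound 2 the gap lies beyond it.

Compound 4, `COc1ccc(-c2nn(-c3ccc(S(N)(=O)=O)cc3)cc2C(CC(=O)c2ccc(Cl)cc2)C(=O)c2ccc(F)cc2)cc1`, is not yet measured. It stands to compound 3 as compound 2 stands to compound 1: the change is methoxy in place of methyl on an aromatic carbon, and the place description is word for word the same as for the pair of compound 1 and compound 2, so the change is taken as the same one on a different core.

Among the measured compounds shown here, for this assay the expectation rests on the single measured instance of the change, namely a number 5 percentage points higher from compound 1 to compound 2 (within the scatter), which was within the scatter, so the step from compound 3 to compound 4 is expected to be small, a number 3.8 percentage points higher from compound 3 to compound 4 (within the scatter), with a wide band because only one prior step on another core is available. Compound 4 is therefore estimated at 60%, between 50% and 70%.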

Compound 4, a percentage reported as inhibition, in the whole organism at one dose (the size of the read-out at that dose, not a potency): 68.1%
Compound 4: middle estimate off by 8.1 percentage points, on the low side; measured number inside the range.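

In this assay, methoxy in place of methyl on an aromatic carbon gives a number 11.9 percentage points higher from compound 3 to compound 4 (beyond the scatter), and set beside the same change on the core of compound 1, the two steps compare as follows: the same change on two cores in this assay, a number 5 percentage points higher (within the scatter) from compound 1 to compound 2 and a number 11.9 percentage points higher (beyond the scatter) from compound 3 to compound 4, 6.9 percentage points apart, within the scatter of two such steps

Among these compounds, the change therefore raises the number on both cores, and these two pairs give no sign that the size of the step depends on the core, although only the step on the second core lies beyond the scatter. This does not establish that the step is of equal size on the two cores, since a pair of single steps can only fail to separate them, and it says nothing about any further core or about potency, as the read-out gives the size of the inhibition at one dose.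

The compounds shown leave open how other groups at this place on the ring would compare with methyl and methoxy, for instance a hydroxyl, an amine, a chlorine or a longer chain such as ethoxy. Among the compounds shown here, they also leave open which of the differences between the two cores matters for the read-out, as compounds 1 and 3 differ in more than one place and no single-place step links the two cores.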